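This account rests on a few compounds, and the source may have more. Where it says the series, first, only, none or still open, it means among the compounds named here.

Three compounds share a quinolone-like scaffold bearing an ethyl group and a fluorinated ring. Compound 1 `CCn1cc(-c2nc3ccccc3o2)c(=O)c2cc(F)c(N3CCNC(C)C3)c(F)c21`, compound 2 `CCn1cc(-c2nc3ccccc3o2)c(=O)c2cc(F)c(N3CCN(C)CC3)cc21` and compound 3 `CCn1cc(-c2nc3ccccc3s2)c(=O)c2cc(F)c(N3CCN(C)CC3)cc21` were all tested in a functional assay on Bel-7402 cells (Homo sapiens) for cytotoxicity, read by MTT assay, with a stated time of 48 h; a lower number here means a stronger inhibitor, a higher number a weaker inhibitor. Compound 1 gives 5700 nM, compound 2 gives 2000 nM and compound 3 gives 24000 nM. Compound 2 and compound 3 differ in one place, (1,3-benzothiazol-2-yl in place of 1,3-benzoxazol-2-yl on an aromatic carbon), and this change produced a 12-fold higher number from compound 2 to compound 3 (1.08 log units; beyond the scatter). Compound 4 `CCn1cc(-c2nc3ccccc3s2)c(=O)c2cc(F)c(N3CCNC(C)C3)c(F)c21` has not yet been tested. It differs from compound 1 by the same change, (1,3-benzothiazol-2-yl in place of 1,3-benzoxazol-2-yl on an aromatic carbon), at the same place. The difference between the core of compound 1 and the core of compound 2 is not broken down here. Among the measured compounds shown here, the step from compound 1 to compound 4 is expected to be roughly an 8.8-fold higher number from compound 1 to compound 4 (0.94 log units; beyond the scatter), resting on the single earlier step of a 12-fold higher number from compound 2 to compound 3 (1.08 log units; beyond the scatter). Compound 4 is therefore estimated at 50000 nM, with a likely range of 15000 nM to 160000 nM.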

Compound 4, half-maximal inhibitory concentration: 15000 nM
Compound 4: the middle estimate sits 3.3-fold (0.52 log units) above what was measured, and the stated range covers the measured number.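

In this assay the 1,3-benzothiazol-2-yl group again gives a weaker compound than 1,3-benzoxazol-2-yl, with a 2.6-fold higher number from compound 1 to compound 4 (0.42 log units; beyond the scatter) as the new step. The direction of the change carries over from one core to the other, but its size does not: the same change on two cores in this assay, a 12-fold higher number (1.08 log units; beyond the scatter) from compound 2 to compound 3 and a 2.6-fold higher number (0.42 log units; beyond the scatter) from compound 1 to compound 4, 4.6-fold (0.66 log units) apart, beyond the scatter of two such steps. The two cores differ in more than one place, so these two pairs cannot show which difference alters the size of the step, and they give no rule for predicting it on a third core.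

The compounds shown leave open how a carboxylic acid or a plain phenyl ring would compare with these two groups at the same place. They also leave open how the change would behave with a longer chain in place of the ethyl group.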